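Longer Acyl Chains Lower the Cytotoxicity Number Stepwise

The compounds below may be only part of what the source reports. "The series", "measured", "known", "first", "only" and "open" are said of these compounds alone.

Compound 1 `CC(=O)Nc1ccn([C@@H]2CO[C@H](CO)O2)c(=O)n1` gives 10700 nM in a functional assay on SW1573 cells (Homo sapiens) for cytotoxicity, read by sulforhodamine B assay, with a stated time of 72 h; a higher number here means a weaker inhibitor, a lower number a stronger inhibitor.
Compound 2 `CCCCCCCCC(=O)Nc1ccn([C@@H]2CO[C@H](CO)O2)c(=O)n1` gives 276 nM in this assay.
Compound 3 `CCCCCCCCCCCCCCCC(=O)Nc1ccn([C@@H]2CO[C@H](CO)O2)c(=O)n1` gives 20 nM in this assay.

Compound 3 has the lowest number of the three; compound 2 sits nearest it and compound 1 furthest, both gaps beyond the scatter. Compound 4 `CCCCCCCCCCCCCCCCCCCCCC(=O)Nc1ccn([C@@H]2CO[C@H](CO)O2)c(=O)n1` differs from compound 3 by hexyl in place of hydrogen on a saturated chain carbon, ten or more bonds along the chain from a carbonyl carbon. Two measured steps lengthened the same chain: a 39-fold lower number from compound 1 to compound 2 (1.59 log units; beyond the scatter) and a 14-fold lower number from compound 2 to compound 3 (1.14 log units; beyond the scatter), the second smaller than the first. A further lengthening is therefore expected to lower the number again, but by less than either step, possibly only within the scatter. Compound 4 is expected to give 12 nM, between 3 nM and 60 nM. The expected step is a 1.7-fold lower number from compound 3 to compound 4 (0.22 log units; within the scatter).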

Compound 4, half-maximal inhibitory concentration: 900 nM
Compound 4: middle estimate off by 75-fold (1.88 log units), on the low side; measured number outside the range, above it.
By their numbers in this assay, from the lowest: compound 3; then compound 2; then compound 4; then compound 1.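

The trend turns at this position: in this assay there is a 45-fold higher number from compound 3 to compound 4 (1.65 log units; beyond the scatter) and so chain length does not lower the number without limit. Among these four compounds the number falls as far as compound 3 and then rises, with compound 4 going against the pattern of the two earlier steps. No measurement here accounts for this reversal.

Open, going by these compounds, is where the lowest number falls among chain lengths from compound 2 to compound 4. Also open, on these data alone, is whether a chain ending in an amine or a carboxylic acid would keep the low number of compound 3.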